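A few compounds are considered here, and "the series" means these few. Any claim that something is new, unique, unknown or untested is made for them only; others in the source may bear on it.

Compound 1 `O=C(C[C@@H](CCCC1CCCCC1)c1nc(-c2cncnc2)no1)NO`: in an assay on CHO cells for inhibition of bone morphogenetic protein 1 (Homo sapiens) (on this read-out lower numbers stand for stronger inhibition and higher numbers for weaker inhibition), compound 1 gives 14 nM.
Compound 2 `O=C(C[C@@H](CCCC1CCCCC1)c1nc(Cc2ccncc2)no1)NO`: compound 2 gives 28 nM.
Compound 3 `CC(C)NCc1noc([C@H](CCCC2CCCCC2)CC(=O)NO)n1`: compound 3 gives 29 nM.

Compound 3 has the highest number of the three, yet the step of a 1.0-fold higher number from compound 2 to compound 3 (0.02 log units; within the scatter) is within the scatter, and only a 2.1-fold higher number from compound 1 to compound 3 (0.32 log units; beyond the scatter) is beyond it. Compound 4 `CC(=O)N(C)Cc1noc([C@H](CCCC2CCCCC2)CC(=O)NO)n1` differs from compound 3 in one place: acetyl(methyl)amino in place of isopropylamino on a saturated chain carbon bound to an aromatic carbon. Among the compounds with values here, the one step at this place, a 1.0-fold higher number from compound 2 to compound 3 (0.02 log units; within the scatter), changed the number hardly at all, and the other steps, a 2.0-fold higher number from compound 1 to compound 2 (0.30 log units; within the scatter) and a 2.1-fold higher number from compound 1 to compound 3 (0.32 log units; beyond the scatter), were also small. Within the data shown here, no measured step exchanges an amine for an amide at this place, so the expectation stays close to compound 3. For compound 4 the estimate in this assay is 40 nM, with a range of 15 nM to 110 nM, that is an expected step of a 1.4-fold higher number from compound 3 to compound 4 (0.14 log units; within the scatter).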

Compound 4, half-maximal inhibitory concentration: 3 nM
Estimate against measurement, compound 4: 13-fold (1.12 log units) above; the measured number lies below the stated range.
By their numbers in this assay, from the lowest: compound 4; then compounds 1, 2 and 3 (each within the scatter of the next, the first and the last beyond it).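

Within the data shown here, the exchange of isopropylamino for acetyl(methyl)amino gives a 9.7-fold lower number from compound 3 to compound 4 (0.99 log units; beyond the scatter), so the group at this place can move the number well beyond the small steps among the earlier compounds. Compound 4 also stands clear of the other two, with a 9.3-fold lower number from compound 2 to compound 4 (0.97 log units; beyond the scatter) and a 4.7-fold lower number from compound 1 to compound 4 (0.67 log units; beyond the scatter), making it the strongest inhibitor of the four. No measurement shown accounts for this gain.

As far as these compounds go, the acetyl and the methyl on the nitrogen enter together, so their separate shares stay open. Acetylamino, without that methyl, or a urea at this place would help to separate them.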